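The compounds below may be only part of what the source reports. "The series", "measured", "known", "first", "only" and "open" are said of these compounds alone.

Measured in a functional assay on DU-145 cells (Homo sapiens) for inhibition, read by CCK-8 assay, with a stated time of 72 h; on this read-out higher numbers stand for weaker inhibition and lower numbers for stronger inhibition:
- Compound 1 `O=C(/C=C/c1cccnc1)NCCCCCc1cccc(S(=O)(=O)Nc2ccccc2)c1`: 140 nM
- Compound 2 `O=C(/C=C/c1cccnc1)NCCCCCCCc1cccc(S(=O)(=O)Nc2ccccc2)c1`: 429 nM
- Compound 3 `Cc1ccc(NS(=O)(=O)c2cccc(CCCCCCNC(=O)/C=C/c3cccnc3)c2)cc1`: 34.4 nM

Compound 3 has the lowest of these three numbers in this assay, and compound 1 and compound 2 both lie beyond the scatter from it. The next compound, compound 4 `Cc1ccc(C)c(NS(=O)(=O)c2cccc(CCCCCCNC(=O)/C=C/c3cccnc3)c2)c1`, has 2,5-dimethylphenyl in place of 4-methylphenyl on a sulfonamide nitrogen. Among the measured compounds shown here, no two measured compounds differ in one place only, so the data say nothing direct about this change. The expectation therefore starts from compound 3 at 34.4 nM. The expected step of a 1.5-fold higher number from compound 3 to compound 4 (0.16 log units; within the scatter) stays within the scatter, with a slight lean toward weaker inhibition. For compound 4 the estimate is 50 nM, with an expected range from 15 nM to 170 nM.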

Compound 4, half-maximal inhibitory concentration: 7.48 nM
Estimate against measurement, compound 4: 6.7-fold (0.83 log units) above, outside the stated range (below it).
By their numbers in this assay, from the lowest: compound 4; then compound 3; then compound 1; then compound 2.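

In this assay the swap of 4-methylphenyl for 2,5-dimethylphenyl on the sulfonamide nitrogen gives a 4.6-fold lower number from compound 3 to compound 4 (0.66 log units; beyond the scatter) and lies beyond the usual scatter. Among the compounds shown here, this is the first comparison here between compounds that differ in one place, and it shows that this position responds to a small change in the ring. No evidence is available to explain the drop.

On these data alone, whether both methyl groups are needed remains open. So does the effect of other groups on this ring, such as chloro, methoxy or an amine.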